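The source may report more compounds than this note shows. Statements on the series, on what has been measured and on what is new or still open speak of the compounds shown alone.

Working notes on a small set of thiosemicarbazide-type analogues.

Compound 1 `COc1cc(C(=O)NNC(=S)Nc2csc(-c3ccccc3)c2)cc(OC)c1OC` and compound 2 `COc1cc(C(=O)NNC(=S)Nc2csc(-c3ccc(C)cc3)c2)cc(OC)c1OC` share one core. Compound 3 `O=C(NNC(=S)Nc1csc(-c2ccccc2)c1)c1ccc(O)cc1` carries a different acyl part on the same general scaffold, and compound 4 `Cc1ccc(-c2cc(NC(=S)NNC(=O)c3ccc(O)cc3)cs2)cc1` is its still unmeasured counterpart.

In a functional assay on Hs 683 cells (Homo sapiens) for inhibition, read by colorimetric assay and MTT assay, with a stated time of 72 h (a higher number here means a weaker inhibitor, a lower number a stronger inhibitor), compound 1 gives 42000 nM. In this assay compound 2 gives 42000 nM. The step of no change at the digits printed from compound 1 to compound 2 (within the scatter) therefore shows that the change methyl in place of hydrogen on an aromatic carbon left the read-out essentially where it was. In this assay compound 3 gives 80000 nM. How compound 3 differs from compound 1 is not broken down here, since the two cores differ in more than one place; their two values lie within the scatter of each other, so no order between them is drawn.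

Compound 4 arises from compound 3 by methyl in place of hydrogen on an aromatic carbon. Going by the values given here, this is the same change as the one from compound 1 to compound 2, made at the same kind of place, on an aromatic carbon of a six-membered aromatic ring of carbon only, para to a large group. Among the compounds with values here, the step of no change at the digits printed from compound 3 to compound 4 (within the scatter) is expected to be flat, because no change at the digits printed from compound 1 to compound 2 (within the scatter) was flat on the neighbouring core; the sample is only one prior pair, so the expectation is weakly founded. For compound 4 in this assay the estimate is 80000 nM, with a range from 40000 nM to 160000 nM.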

Compound 4, half-maximal inhibitory concentration: 49000 nM
Beside the measured number, compound 4's estimate is 1.6-fold (0.21 log units) above it; low and high end bracket the measured number.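

In this assay, replacing phenyl with 4-methylphenyl gives a 1.6-fold lower number from compound 3 to compound 4 (0.21 log units; within the scatter), so the methyl group in place of hydrogen leaves the read-out within the scatter on this core as well. Set beside the earlier step on the core of compound 1, the two steps do not differ, and the change carries over between these two cores: the same change on two cores in this assay, no change at the digits printed (within the scatter) from compound 1 to compound 2 and a 1.6-fold lower number (0.21 log units; within the scatter) from compound 3 to compound 4, 1.6-fold (0.21 log units) apart, within the scatter of two such steps

Going by these compounds alone, this agreement rests on only two pairs in a single assay. Neither step stands out from the scatter. The agreement shows that the change was flat twice, not that a change of real size would carry over in the same way, nor that the same would hold on a third core.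

The compounds shown hold only hydrogen or methyl on this aromatic carbon, para to a large group, so it remains open whether a different group there, such as a chlorine atom, a methoxy group, an amine or a carboxylic acid, would move the read-out beyond the scatter. Also open, going by these compounds, is how the methyl group would behave at other places on that ring, and whether the flat result would hold with a longer chain in its place.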